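The compounds below may be only part of what the source reports. "The series", "measured", "known", "first", "only" and "open" are said of these compounds alone.

Going by the values given here, in a functional assay on THP-1 cells (Homo sapiens) for cytotoxicity, read by sulforhodamine B assay, with a stated time of 48 h (on this read-out higher numbers stand for weaker inhibition and lower numbers for stronger inhibition), compound 1 (`COc1cc(/C=C/C(=O)/C=C/c2cccc3ccccc23)ccc1OCc1cn(CCCOc2cc(=O)oc3ccccc23)nn1`) gives 8410 nM, the higher of the two numbers measured so far. Compound 2 (`COc1cc(/C=C/C(=O)/C=C/c2cc(OC)c(OC)c(OC)c2)ccc1OCc1cn(CCOc2cc(=O)oc3ccccc23)nn1`) gives 820 nM, and the gap between them lies beyond the usual scatter. Compound 3 (`COc1ccc(/C=C/C(=O)/C=C/c2ccc(OCc3cn(CCCOc4cc(=O)oc5ccccc45)nn3)c(OC)c2)cc1OC`) has yet to be measured. It departs from compound 1 in one place: 3,4-dimethoxyphenyl in place of naphthalen-1-yl on a double-bonded chain carbon bound to a double-bonded chain carbon. That is, 3,4-dimethoxyphenyl stands in place of naphthalen-1-yl on a double-bonded chain carbon bound to a double-bonded chain carbon. Among the compounds with values here, no two measured compounds differ in one place only, so this assay offers no direct precedent for this change. Within the data shown here, the only guide is compound 2, which also lacks naphthalen-1-yl and reads 820 nM, though it differs from compound 1 elsewhere too. A moderate move towards stronger inhibition, beyond the scatter, is therefore expected, with an estimated 3.0-fold lower number from compound 1 to compound 3 (0.48 log units; beyond the scatter). For compound 3 the estimated value is 2800 nM, with an expected range of 900 nM to 8000 nM.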

Compound 3, half-maximal inhibitory concentration: 8510 nM
For compound 3 the middle estimate is 3.0-fold (0.48 log units) below the measured one, and the stated range ends below it.
By their numbers in this assay, from the lowest: compound 2; then compounds 1 and 3 (each within the scatter of the next).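

In this assay, going by these compounds alone, the step of a 1.0-fold higher number from compound 1 to compound 3 (0.01 log units; within the scatter) gives the first direct reading at this place, on a double-bonded chain carbon bound to a double-bonded chain carbon. Replacing naphthalen-1-yl, with its two six-membered aromatic rings of carbon only, by 3,4-dimethoxyphenyl, with one such ring and two hydrogen-bond acceptors, leaves the number within the scatter, so on the core of compound 1 this assay does not separate the two groups. Nothing shown accounts for the two groups reading alike.

This single pair leaves open whether the same holds for other groups at this place, such as one carrying an amine or a carboxylic acid. It also leaves open whether the result would persist on a core with a longer chain in its linker.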